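Swapping a dimethyl-oxazole for chlorophenyl in a cytotoxicity series

The source may hold more compounds than are shown below. What is called first, only, known or untested is meant among the compounds shown, and "the series" means these compounds.

Compound 1 `Cc1noc(C)c1C(c1ccccc1)N1CCN(c2ncnc3c2cnn3-c2ccccc2)CC1` sits at the edge of what the measurement can see. In a functional assay on cells (Rhabdomyosarcoma cell, Homo sapiens) for cytotoxicity (on this read-out higher numbers stand for weaker inhibition and lower numbers for stronger inhibition), compound 1 gives > 25000 nM, which is a limit of the assay rather than a number. Compound 2 `Cc1ccsc1C(c1ccccn1)N1CCN(c2ncnc3c2cnn3-c2ccccc2)CC1` is measured at the same edge. In this assay compound 2 gives > 25000 nM, again only a limit. Compound 3 `N#Cc1ccc(C(c2ccccc2)N2CCN(c3ncnc4c3cnn4-c3ccccc3)CC2)cc1` is no different. In this assay compound 3 gives > 25000 nM, also a limit. All three measured values therefore sit in one place, (the limit of > 25000 nM in this assay, at which 3 of the 3 values shown sit).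

The change to be followed leads to compound 4 `Clc1ccc(C(c2ccccc2)N2CCN(c3ncnc4c3cnn4-c3ccccc3)CC2)cc1`: 4-chlorophenyl in place of 3,5-dimethyl-1,2-oxazol-4-yl on a saturated chain carbon bound to an amine nitrogen in a ring and an aromatic carbon. For the measured compounds named here, the only measured step that touches the same position is the one from compound 1 to compound 3, a step that the two limits leave unreadable from compound 1 to compound 3. Going by the values given here, the two limits leave its size unreadable, so it offers no direction to expect, and no other measured step speaks to this change.

Among the compounds with values here, with every measured compound at the limit and no step of readable size, the expectation for compound 4 is that this assay again reports only a limit. The step from compound 1 to compound 4 is estimated at a step that the limit leaves unreadable from compound 1 to compound 4, nothing beyond the scatter. Compound 4 is expected at 30000 nM, with a range from 10000 nM to 100000 nM.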

Compound 4, half-maximal inhibitory concentration: > 25000 nM
Compound 4: a limit, no number; the forecaster's own chance of this, stated with the estimate: 85%; the middle value lies beyond the limit too.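

Compound 4 is also only a limit, so neither the step from compound 1 to compound 4 nor the step from compound 3 to compound 4 can be read: the limit of > 25000 nM in this assay, at which 4 of the 4 values shown sit.

The compounds shown leave open how far apart compound 1, compound 3 and compound 4 truly lie in this assay, and whether any group at this place gives a real number there.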